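A few compounds are considered here, and "the series" means these few. Any claim that something is new, unique, unknown or untested is made for them only; others in the source may bear on it.

Working notes on the series.

Of the compounds shown here, three have been measured so far in a functional assay on Caco-2 cells (Homo sapiens) for inhibition, read by MTT assay, with a stated time of 48 h, tested at 10 uM; on this read-out lower numbers stand for less inhibition of growth and higher numbers for more inhibition of growth at the one concentration tested. Compound 1, `Cc1cc(=O)c2c(O)cc(OC/C=C/c3ccccc3)c([C@H]3CCN(C)C[C@H]3O)c2o1`, gives 9%. Compound 2, `CCN(CC)Cc1c(O)c([C@H]2CCN(C)C[C@H]2O)c2oc(C)cc(=O)c2c1O`, gives 17%. Compound 3, `Cc1oc2c([C@H]3CCN(C)C[C@H]3O)c(O)cc(O)c2c(=O)c1C(O)c1ccc([N+](=O)[O-])cc1`, gives 5%.

Compound 3 holds the lowest number of the three. Its nearest neighbour on this read-out is compound 1, whose value lies within the usual scatter of compound 3, so no order can be read between these two. Compound 2 lies furthest from compound 3, and that gap is beyond the scatter. Among the measured compounds shown here, no pair among the measured compounds differs in a single place, so no measured step is available for this assay.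

Compound 4, `Cc1oc2c([C@H]3CCN(C)C[C@H]3O)c(O)cc(O)c2c(=O)c1C(O)c1ccc(F)cc1`, has not yet been measured. It differs from compound 3 in one place: fluoro in place of nitro on an aromatic carbon. For the measured compounds named here, the data give no measured step for this kind of change, and all three measured values sit at the low end of the read-out. The step from compound 3 to compound 4 is therefore expected to be small, a number 3 percentage points higher from compound 3 to compound 4 (within the scatter), and not beyond the scatter in either direction. For compound 4 the expected value in this assay is 8%, within a range from 0% to 20%.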

Compound 4, percent growth inhibition at one concentration: 11%
Compound 4: the middle estimate sits 3 percentage points below what was measured, within the range that was stated.
By their numbers in this assay, from the lowest: compounds 3, 1, 4 and 2 (each within the scatter of the next, the first and the last beyond it).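

In this assay the series now has its first measured step at a single place: fluoro in place of nitro on an aromatic carbon, para to a large group, gives a number 6 percentage points higher from compound 3 to compound 4 (within the scatter). The change from 4-nitrophenyl to 4-fluorophenyl replaces a group of 3 heavy atoms and 2 hydrogen-bond acceptors with one of 1 heavy atom and 0 hydrogen-bond acceptors, yet this assay does not separate the two compounds, so this exchange at this position leaves the number within the usual scatter. Nothing in the available data accounts for the size of this step.

The compounds shown leave open whether a dimethylamino group or a carboxylic acid on the same aromatic carbon would give a step beyond the scatter, as this single exchange covers only nitro and fluoro. Among the compounds shown here, they also leave open whether the same exchange would give a comparable step on another core of the series, since only this one pair carries it and the read-out rests on the one concentration tested.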